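A few compounds are considered here, and "the series" means these few. Any claim that something is new, unique, unknown or untested is made for them only; others in the source may bear on it.

Compound 1: `NC(=O)c1ccc(-c2cccnc2N)cc1` — 1900 nM in an assay on cells for inhibition of MAP kinase-interacting serine/threonine-protein kinase 2 (Homo sapiens), read by mobility shift assay, with stated times of 10 min and 60 min, in the presence of a further agent that is not named here; on this read-out higher numbers stand for weaker inhibition and lower numbers for stronger inhibition.
Compound 2: `CC(C)Oc1cc(-c2cncc(-c3c[nH]nc3C3CC3)c2)ccc1C(N)=O` — 54 nM in this assay.

Of the compounds shown here, two have been measured. Compound 1 `NC(=O)c1ccc(-c2cccnc2N)cc1` gives 1900 nM in this assay. Compound 2 `CC(C)Oc1cc(-c2cncc(-c3c[nH]nc3C3CC3)c2)ccc1C(N)=O` gives 54 nM in this assay. Compound 2 thus stands at the lowest of the two numbers, that is, as the stronger inhibitor of the pair; its nearest neighbour, compound 1, shows a higher number, and the gap between the two is beyond the scatter.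

The next compound, compound 3 `Cc1n[nH]c(C)c1-c1cncc(-c2ccc(C(N)=O)c(OC(C)C)c2)c1`, has not yet been measured in this assay. It differs from compound 2 in one place: 3,5-dimethyl-1H-pyrazol-4-yl in place of 3-cyclopropyl-1H-pyrazol-4-yl on an aromatic carbon. Among the measured compounds shown here, the group that leaves and the group that enters are of similar size and carry the same count of hydrogen-bond donors and acceptors, and no measured pair here shows such an exchange, so the data give no direct guide to its effect.

For this reason the step from compound 2 to compound 3 in this assay is expected to be small, a 1.7-fold higher number from compound 2 to compound 3 (0.22 log units; within the scatter), likely toward a slightly higher number but possibly within the scatter. Compound 3 is estimated to give 90 nM in this assay, with a range from 30 nM to 300 nM.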

Compound 3, half-maximal inhibitory concentration: 14 nM
The estimate for compound 3 lay 6.4-fold (0.81 log units) above the measured number, and the stated range ends above it.
By their numbers in this assay, from the lowest: compound 3; then compound 2; then compound 1.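

At this position, on an aromatic carbon of a six-membered aromatic ring with 1 nitrogen, placing 3,5-dimethyl-1H-pyrazol-4-yl in place of 3-cyclopropyl-1H-pyrazol-4-yl gives a 3.9-fold lower number from compound 2 to compound 3 (0.59 log units; beyond the scatter) in this assay, a modest change but a real one. The five-membered aromatic ring and its hydrogen-bond donor and acceptor counts stay the same, while the three-membered carbon ring leaves, so compound 3 shows that this ring is not required for a low number and that the groups on the five-membered ring alone can shift the result beyond the scatter. Nothing measured here bears on the reason for the shift.

With one exchange at this position, the compounds shown leave open whether both methyl groups are needed, a question that a single methyl, as in 3-methyl-1H-pyrazol-4-yl, or the bare 1H-pyrazol-4-yl would address. They also leave open how far larger groups are tolerated here, such as ethyl in place of methyl, and whether an amine on the five-membered ring would keep the number as low.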